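Fluoro to chloro on the sulfonyl-bearing ring

The source may report more compounds than this note shows. Statements on the series, on what has been measured and on what is new or still open speak of the compounds shown alone.

Compound 1 `O=S(=O)(/C=C/c1cccnc1)c1cccc(Cl)c1`: 3520 nM
Compound 2 `O=S(=O)(/C=C/c1ccncc1)c1cccc(F)c1`: 950 nM

Of the compounds shown here, two have been measured in an assay on U2OS cells for activation of nuclear factor erythroid 2-related factor 2 (Homo sapiens), read by beta-arrestin recruitment, with a stated time of 6 h; a higher number here means that more compound is needed for the effect, a lower number that less compound is needed. Compound 1 gives 3520 nM, and compound 2 gives 950 nM. Of the two numbers, compound 2 stands at the lower one, and the gap to compound 1 lies beyond the scatter. Compounds 1 and 2 differ in more than one place, so their two values show only that difference, not a single step.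

Compound 3 `O=S(=O)(/C=C/c1ccncc1)c1cccc(Cl)c1` has not yet been measured. It differs from compound 2 by chloro in place of fluoro on an aromatic carbon. Going by the values given here, no step between measured compounds isolates this change, so there is no direct precedent. Compound 3 is expected to stay close to compound 2, with a small shift toward a higher number estimated as a 1.4-fold higher number from compound 2 to compound 3 (0.14 log units; within the scatter), which may well lie within the scatter. For compound 3 the estimated value in this assay is 1300 nM, with a range from 500 nM to 3500 nM.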

Compound 3, half-maximal effective concentration: 528 nM
Beside the measured number, compound 3's estimate is 2.5-fold (0.39 log units) above it, within the range that was stated.
By their numbers in this assay, from the lowest: compounds 3 and 2 (each within the scatter of the next); then compound 1.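

On this aromatic carbon, meta to a large group, chloro in place of fluoro gives a 1.8-fold lower number from compound 2 to compound 3 (0.26 log units; within the scatter) in this assay, so compound 2 and compound 3 cannot be told apart in this assay. Going by these compounds alone, this is the first reading of that change alone, and it shows that the exchange of these two halogens leaves the number within the scatter. With chloro held in place, pyridin-4-yl in place of pyridin-3-yl on the double-bonded chain carbon gives a 6.7-fold lower number from compound 1 to compound 3 (0.82 log units; beyond the scatter), and of the two single changes read here only this one lies beyond the scatter.

As far as these compounds go, whether a bromo, methoxy or nitrile group on the same aromatic carbon would move the number further, or whether the hydrogen there would serve as well, remains open. No measurement given here explains either step.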